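Aryl swap on the pyrazolyl-bearing core: methoxyphenyl to chlorophenyl

The source may report more compounds than this note shows. Statements on the series, on what has been measured and on what is new or still open speak of the compounds shown alone.

Three members of the series have numbers in a functional assay, with a stated time of 150 min; a lower number here means a stronger inhibitor, a higher number a weaker inhibitor. Compound 1 `CCOC(=O)c1cnn(-c2nc(-c3ccc(OC)cc3)c(C#N)c(=O)n2C)c1N` gives 79 ug/mL in this assay. Compound 2 `CN(C)c1ccc(-c2nc(NN)n(C)c(=O)c2C#N)cc1` gives 69 ug/mL in this assay, and compound 3 `Cn1c(NN)nc(-c2cccc(O)c2O)c(C#N)c1=O` gives 44 ug/mL in this assay. Compound 1 has the highest of the three numbers, but its gap to compound 2 and its gap to compound 3 both fall within the usual scatter of repeated measurements, so the three cannot be told apart on these data. Going by the values given here, no two measured compounds differ in a single place, so no measured step is available to calibrate any structural change.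

Compound 4 `CCOC(=O)c1cnn(-c2nc(-c3ccccc3Cl)c(C#N)c(=O)n2C)c1N` is the next compound to be measured. It differs from compound 1 in one place: 2-chlorophenyl in place of 4-methoxyphenyl on an aromatic carbon. The rest of the core is unchanged.

Among the compounds with values here, with no measured step to lean on, and with the three aryl variants so far all giving numbers within the scatter of one another, the expectation for this change is no step beyond the scatter in either direction. The step from compound 1 to compound 4 is estimated as a 1.1-fold lower number from compound 1 to compound 4 (0.02 log units; within the scatter). Compound 4 is accordingly expected to give about 75 ug/mL in this assay, with a range of 35 ug/mL to 160 ug/mL.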

Compound 4, half-maximal inhibitory concentration: 93 ug/mL
Compound 4: middle estimate off by 1.2-fold (0.09 log units), on the low side, within the range that was stated.
By their numbers in this assay, from the lowest: compounds 3, 2, 1 and 4 (each within the scatter of the next, the first and the last beyond it).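

In this assay, the series now has its first single-place step, a 1.2-fold higher number from compound 1 to compound 4 (0.07 log units; within the scatter), so this aromatic carbon, next to the ring nitrogen and ortho to a cyano group, accepts 2-chlorophenyl in place of 4-methoxyphenyl with no change that can be read. The swap also removes the hydrogen-bond acceptor counted on 4-methoxyphenyl and puts chlorine in place of the methoxy group, and on the shared core of compound 1 and compound 4 this exchange stays within the scatter. No supporting measurement bears on why the number holds across this change.

Going by these compounds alone, the single step changes both the identity of the phenyl substituent and where it sits on the ring, so 4-chlorophenyl or 2-methoxyphenyl would be needed to separate the two, and unsubstituted phenyl would show whether either substituent matters at all. As far as these compounds go, whether any group at this carbon can move the number beyond the scatter remains open, as does the role of the rest of the core, where a carboxylic acid or a primary amide in place of the ethyl ester would be a direct test.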